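Chain Lengthening Toward a Dimethylamino Terminus

The compounds below may be only part of what the source reports. "The series", "measured", "known", "first", "only" and "open" are said of these compounds alone.

Three compounds have so far been measured in a physicochemical assay for lipophilicity, using the shake flask method, measured as octanol-water partition, at pH 7.4; on this read-out lower numbers stand for lower lipophilicity and higher numbers for higher lipophilicity:

Compound 1, `COc1cc(/C=C/C(=O)Nc2ccccc2)ccc1OCCCN1CCCCC1`: 1.58
Compound 2, `COc1cc(/C=C/C(=O)Nc2ccccc2)ccc1OCCCN1CCCC1`: 1.57
Compound 3, `COc1cc(/C=C/C(=O)Nc2ccccc2)ccc1OCCCCCN1CCCC1`: 1.64

Compound 3 gives the highest of the three numbers, but the steps reaching it, a number 0.06 log units higher from compound 1 to compound 3 (within the scatter) and a number 0.07 log units higher from compound 2 to compound 3 (within the scatter), are both within the scatter, so the three values cannot be told apart. Compound 4, `COc1cc(/C=C/C(=O)Nc2ccccc2)ccc1OCCCCCCCCCCN(C)C`, differs from compound 3 by 5-(dimethylamino)pentyl in place of pyrrolidin-1-yl on a saturated chain carbon, five bonds along the chain from an oxygen on an aromatic ring. Among the compounds with values here, the steps that bear on this are the chain lengthenings a number 0.07 log units higher from compound 2 to compound 3 (within the scatter) and a number 0.06 log units higher from compound 1 to compound 3 (within the scatter), each within the scatter; the change to compound 4 is larger and has no measured counterpart. A modest rise in this assay is expected, a number 0.26 log units higher from compound 3 to compound 4 (within the scatter), possibly still within the scatter. Compound 4 is estimated at 1.9, between 1.4 and 2.5.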

Compound 4, partition coefficient: 1.8
Compound 4: middle estimate off by 0.10 log units, on the high side; the measured number falls inside the stated range.
By their numbers in this assay, from the lowest: compounds 2, 1, 3 and 4 (each within the scatter of the next).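

In this assay, a number 0.16 log units higher from compound 3 to compound 4 (within the scatter) shows that replacing pyrrolidin-1-yl with the ring-free 5-(dimethylamino)pentyl, on a saturated chain carbon, five bonds along the chain from an oxygen on an aromatic ring, still leaves the two compounds unseparated. The wider steps a number 0.23 log units higher from compound 2 to compound 4 (within the scatter) and a number 0.22 log units higher from compound 1 to compound 4 (within the scatter) read the same way, so the four compounds cannot be told apart on this read-out. No measurement at hand accounts for this result. Going by these compounds, whether a carboxylic acid or a morpholine in place of the terminal amine, or a still longer chain, would give a step beyond the scatter stays open.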